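The source may hold more compounds than are shown below. What is called first, only, known or untested is meant among the compounds shown, and "the series" means these compounds.

Compound 1 `Cc1ccc(-c2ccnc(C(=O)Nc3ccc(Oc4ccnc5[nH]ccc45)cc3)c2)cc1`: in a functional assay on MCF7 cells (Homo sapiens) for cytotoxicity, read by MTT assay, with a stated time of 72 h (on this read-out lower numbers stand for stronger inhibition and higher numbers for weaker inhibition), compound 1 gives > 10000 nM, which is a limit of the assay rather than a number.
Compound 2 `O=C(Nc1ccc(Oc2ccnc3[nH]ccc23)cc1)c1cc(-c2ccccc2)ccn1`: in this assay compound 2 gives 3750 nM.
Compound 3 `Cc1ccc(-c2ccnc(C(=O)Nc3ccc(Oc4ccnc5[nH]ccc45)c(F)c3)c2)cc1`: in this assay compound 3 gives 8430 nM.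

The change from compound 2 to compound 1 is methyl in place of hydrogen on an aromatic carbon. It brought an at least 2.6-fold higher number from compound 2 to compound 1 (0.42 log units; beyond the scatter), and compound 1 rests at the limit of > 10000 nM in this assay, at which 1 of the 3 values shown sits. Compound 3 differs from compound 2 in more than one place, so the difference between the two cores is not broken down here; between them the step is an at least 1.1-fold lower number from compound 1 to compound 3 (0.07 log units; that floor lies within the scatter).

Compound 4 `Cc1ccc(-c2ccnc(C(=O)Nc3ccc(Oc4ccnc5[nH]ccc45)c(F)c3)c2)c(C)c1` is not yet measured. From compound 3 it differs by methyl in place of hydrogen on an aromatic carbon. This is the same kind of change as from compound 2 to compound 1, not the same: in the earlier case the methyl enters para to a large group, here it enters ortho to a large group and meta to a methyl group. In this assay the step is expected to be a 1.8-fold higher number from compound 3 to compound 4 (0.25 log units; within the scatter), beside the earlier at least 2.6-fold higher number from compound 2 to compound 1 (0.42 log units; beyond the scatter), resting on that step and on compound 3 giving 8430 nM. Compound 4 is therefore estimated at 15000 nM in this assay, expected between 6000 nM and 40000 nM, and a limit is quite possible.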

Compound 4, half-maximal inhibitory concentration: 6220 nM
Compound 4: middle estimate off by 2.4-fold (0.38 log units), on the high side; measured number inside the range.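

In this assay, the methyl that turns the 4-methylphenyl of compound 3 into the 2,4-dimethylphenyl of compound 4 brought a 1.4-fold lower number from compound 3 to compound 4 (0.13 log units; within the scatter), so on this core the change gave no step beyond the scatter. Set beside the earlier case, methyl in place of hydrogen on an aromatic carbon did not carry over from one core to the other as a step of one size: the same change on two cores in this assay, an at least 2.6-fold higher number (0.42 log units; beyond the scatter) from compound 2 to compound 1 and a 1.4-fold lower number (0.13 log units; within the scatter) from compound 3 to compound 4, at least 3.6-fold (0.55 log units) apart, beyond the scatter of two such steps. Going by these compounds, compound 1 gives > 10000 nM, which is a limit of the assay and not a number, so the full size of the earlier step stays unknown, and two pairs do not show why the steps part or how the change would read on any other core.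

The compounds shown leave open whether the 2,4-dimethylphenyl group would read the same on the core of compound 1, which carries no fluoro group. They also leave open what a methoxy group, a chlorine or an amine would give at the place this methyl takes.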